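This account rests on a few compounds, and the source may have more. Where it says the series, first, only, none or still open, it means among the compounds named here.

Measured in a functional assay on A549 cells (Homo sapiens) for cytotoxicity, read by WST assay, with a stated time of 24 h; a lower number here means a stronger inhibitor, a higher number a weaker inhibitor:
Compound 1 `COc1ccc2c(/C=C(\C#N)C(=O)c3c[nH]c4cc(OC)ccc34)c[nH]c2c1`: 1900 nM
Compound 2 `COc1ccc2c(C(=O)/C(C#N)=C/c3c[nH]c4ccc(OC)cc34)c[nH]c2c1`: 3700 nM

Compound 2, at 3700 nM, lies within the scatter of compound 1, at 1900 nM, so the two values set no order. Compound 3 `COc1ccc2c(C(=O)/C(C#N)=C/c3c[nH]c4ccccc34)c[nH]c2c1` differs from compound 2 by one change: hydrogen in place of methoxy on an aromatic carbon. Within the data shown here, no measured pair shows this change, so any expectation is loose. In this assay, no shift beyond the scatter is expected, and no direction is favoured. The estimated 1.2-fold lower number from compound 2 to compound 3 (0.09 log units; within the scatter) is therefore small. For compound 3 the estimated value is 3000 nM, with an expected range of 1000 nM to 9000 nM.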

Compound 3, half-maximal inhibitory concentration: 6400 nM
The estimate for compound 3 lay 2.1-fold (0.33 log units) below the measured number; the measured number falls inside the stated range.
By their numbers in this assay, from the lowest: compounds 1, 2 and 3 (each within the scatter of the next, the first and the last beyond it).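

In this assay, hydrogen in place of methoxy on an aromatic carbon gives a 3.4-fold higher number from compound 1 to compound 3 (0.53 log units; beyond the scatter), a modest step beyond the scatter, whereas the same kind of change gives a 1.7-fold higher number from compound 2 to compound 3 (0.24 log units; within the scatter), which stays within the scatter. Loss of a methoxy from the core therefore registers only when read from compound 1, so the size of the effect depends on the compound of reference. No evidence on the origin of this difference is available.

On these data alone, whether an ethoxy group, a fluorine or an amine at this aromatic carbon would move the number remains open. Also open, as far as these compounds go, is whether the methoxy on the other fused ring system contributes, since all three compounds carry it.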